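Replacing the isoquinoline ring on the urea: solubility estimate

This account rests on a few compounds, and the source may have more. Where it says the series, first, only, none or still open, it means among the compounds named here.

Measured compounds:
- compound 1 `C[C@@H]1CN([C@@H](C)CO)C(=O)c2cccc(NC(=O)Nc3cncc4ccccc34)c2O[C@H]1CN(C)S(=O)(=O)c1ccc2c(c1)OCCO2`: 84900 nM
- compound 2 `C[C@@H]1CN([C@@H](C)CO)C(=O)c2cccc(NC(=O)Nc3cccc4cccnc34)c2O[C@H]1CN(C)S(=O)(=O)c1ccc2c(c1)OCCO2`: 1800 nM
- compound 3 `C[C@@H]1CN([C@@H](C)CO)C(=O)c2cccc(NC(=O)Nc3nccc4ccccc34)c2O[C@H]1CN(C)S(=O)(=O)c1ccc2c(c1)OCCO2`: 700 nM

These three compounds share one core and differ only in the bicyclic aromatic group on the urea nitrogen. In a physicochemical assay for solubility, read by HPLC, in phosphate buffer, measured as thermodynamic solubility, with a stated time of 24 h, at pH 7.4 (a lower number here means a less soluble compound, a higher number a more soluble compound), compound 1 gives 84900 nM, the highest of the three numbers. Swapping its isoquinolin-4-yl group gave large drops in both measured cases: a 47-fold lower number from compound 1 to compound 2 (1.67 log units; beyond the scatter) and a 120-fold lower number from compound 1 to compound 3 (2.08 log units; beyond the scatter). Between the two alternatives the gap was smaller, a 2.6-fold lower number from compound 2 to compound 3 (0.41 log units; beyond the scatter).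

Compound 4 `C[C@@H]1CN([C@@H](C)CO)C(=O)c2cccc(NC(=O)Nc3cccc4ccccc34)c2O[C@H]1CN(C)S(=O)(=O)c1ccc2c(c1)OCCO2` has not yet been measured in this assay. It differs from compound 1 by naphthalen-1-yl in place of isoquinolin-4-yl on an amide-type nitrogen. Going by the values given here, both measured steps that change this same group on compound 1 were large and downward, so a large downward step is expected here as well; the incoming group carries no hydrogen-bond acceptor, and the data hold no example with that feature, so the size is uncertain. For compound 4 a solubility of 500 nM is estimated, within a range of 100 nM to 3000 nM, which means an expected step of a 170-fold lower number from compound 1 to compound 4 (2.23 log units; beyond the scatter).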

Compound 4, solubility: 100 nM
Compound 4: middle estimate off by 5.0-fold (0.70 log units), on the high side; measured number inside the range.
By their numbers in this assay, from the lowest: compound 4; then compound 3; then compound 2; then compound 1.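

In this assay, naphthalen-1-yl, whose two six-membered aromatic rings are carbon only, gives the lowest number of the series on the amide-type nitrogen: an 850-fold lower number from compound 1 to compound 4 (2.93 log units; beyond the scatter), along with an 18-fold lower number from compound 2 to compound 4 (1.26 log units; beyond the scatter) and a 7.0-fold lower number from compound 3 to compound 4 (0.85 log units; beyond the scatter). The earlier compounds shown here compared only different placements of a ring nitrogen, while this result adds a group of the same 10 heavy atoms with no ring nitrogen, and all three nitrogen-containing groups give higher numbers than it does. No measurement available here explains these differences.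

The compounds shown leave open how a smaller single-ring group, such as phenyl or pyridin-3-yl, would compare on this nitrogen. They also leave open whether adding an amine or a carboxylic acid to naphthalen-1-yl would raise the number.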